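Methyl to Hydrogen on the Aromatic Nitrogen of Compound 1

The compounds below may be only part of what the source reports. "The series", "measured", "known", "first", "only" and "open" are said of these compounds alone.

Compound 1 `Cn1c(/C=C/C(=O)c2ccccc2O)cc(Br)c1Br` gives 2510 nM in a functional assay on MCF7 cells (Homo sapiens) for cytotoxicity, read by MTT assay, with stated times of 6 h and 48 h (a higher number here means a weaker inhibitor, a lower number a stronger inhibitor), the second highest of the three numbers measured. Compound 3 `Cn1c(/C=C/C(=O)c2cc(O)ccc2O)cc(Br)c1Br` lies at 320 nM, reached by the step of a 7.8-fold lower number from compound 1 to compound 3 (0.89 log units; beyond the scatter). Compound 2 `Cn1c(/C=C/C(=O)c2ccccc2)cc(Br)c1Br` lies at 35400 nM, reached by the step of a 14-fold higher number from compound 1 to compound 2 (1.15 log units; beyond the scatter). Compound 4 `O=C(/C=C/c1cc(Br)c(Br)[nH]1)c1ccccc1O` differs from compound 1 by hydrogen in place of methyl on an aromatic nitrogen. Both measured steps concern a hydroxy group on an aromatic carbon, not the aromatic nitrogen, so neither bears on this change, and no step beyond the scatter is expected in this assay in either direction. Compound 4 is therefore estimated at 2500 nM, within a range of 800 nM to 8000 nM, which means an expected step of a 1.0-fold lower number from compound 1 to compound 4 (0.00 log units; within the scatter).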

Compound 4, half-maximal inhibitory concentration: 1490 nM
For compound 4 the middle estimate is 1.7-fold (0.22 log units) above the measured one; the range from low to high includes it.
By their numbers in this assay, from the lowest: compound 3; then compounds 4 and 1 (each within the scatter of the next); then compound 2.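

In this assay the change gives a 1.7-fold lower number from compound 1 to compound 4 (0.23 log units; within the scatter), so hydrogen can stand in place of methyl on this aromatic nitrogen without a step beyond the scatter. For the compounds shown here, this is the first view of that nitrogen, as the earlier steps changed only hydroxy groups on an aromatic carbon. Nothing shown explains this result.

As far as these compounds go, whether an ethyl group, a longer chain or a chain ending in a carboxylic acid on this nitrogen would keep the number stays open. So does whether the hydroxy steps carry over to compound 4.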